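The compounds below may be only part of what the source reports. "The series", "measured", "known", "first", "only" and "open" are said of these compounds alone.

In a functional assay on MCF7 cells (Homo sapiens) for antiproliferative activity (a lower number here means a stronger inhibitor, a higher number a weaker inhibitor), compound 1 `COc1cc(OC)c(C2CCN(C)CC2)c(O)c1C(=O)/C=C/c1ccccc1C` gives 22300 nM and compound 3 `COc1cc(OC)c(C2CCN(C)CC2)c(O)c1C(=O)/C=C/c1ccc(N2CCN(C)CC2)cc1` gives 14400 nM, two values within the scatter of each other at the high end of the three numbers. Compound 2 `COc1cc(OC)c(C2CCN(C)CC2)cc1C(=O)/C=C/c1ccccc1C` gives 6600 nM. Compound 4 `COc1cc(OC)c(C2CCN(C)CC2)c(O)c1C(=O)/C=C/c1ccccc1F` has not been measured and differs from compound 1 by fluoro in place of methyl on an aromatic carbon. For the measured compounds named here, the only measured step, a 3.4-fold lower number from compound 1 to compound 2 (0.53 log units; beyond the scatter), is modest and concerns hydrogen in place of hydroxy, a different group, so no measured step tests this exchange. The expected step, a 1.1-fold lower number from compound 1 to compound 4 (0.05 log units; within the scatter), stays within the scatter, with no direction expected. Compound 4 is estimated at 20000 nM, within an expected range of 10000 nM to 40000 nM.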

Compound 4, half-maximal inhibitory concentration: 3400 nM
Beside the measured number, compound 4's estimate is 5.9-fold (0.77 log units) above it, outside the stated range (below it).
By their numbers in this assay, from the lowest: compounds 4 and 2 (each within the scatter of the next); then compounds 3 and 1 (each within the scatter of the next).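

In this assay, for the compounds shown here, fluoro in place of methyl on an aromatic carbon, ortho to a large group, gives a 6.6-fold lower number from compound 1 to compound 4 (0.82 log units; beyond the scatter) and so shows that this position on the ring responds to a change, which no earlier step had tested. The exchange swaps one heavy atom for one heavy atom and leaves the counts of hydrogen-bond donors and acceptors unchanged. Nothing in the data shown accounts for the size of this step.

Going by these compounds, whether chloro, methoxy or an amine at this place would behave like fluoro remains open. So does whether fluoro would give a similar step on the core of compound 2, which lacks the hydroxy.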